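This account rests on a few compounds, and the source may have more. Where it says the series, first, only, none or still open, it means among the compounds named here.

In a functional assay on NALM-6 cells (Homo sapiens) for cytotoxicity, with a stated time of 72 h (a lower number here means that less compound is needed, a higher number that more compound is needed for the effect), compound 1 (`C=C[C@@](C)(/C=C/c1ccc(OS(=O)(=O)C(F)(F)F)cc1)CCC=C(C)C`) gives > 43400 nM as a limit of the assay, not a number. Compound 2 (`C=C[C@@](C)(/C=C/c1ccc(Nc2ccc(F)cc2)cc1)CCC=C(C)C`) gives > 43400 nM as a limit too, so it offers no exact starting value. The picture so far is the limit of > 43400 nM in this assay, at which 2 of the 2 values shown sit, and nothing more. Within the data shown here, the one measured step is a step that the two limits leave unreadable from compound 1 to compound 2 and it brought (4-fluorophenyl)amino in place of ((trifluoromethyl)sulfonyl)oxy on an aromatic carbon, so it gives no size to carry forward. Compound 3 (`C=C[C@@](C)(/C=C/c1ccc(Nc2cc(F)c(F)cc2F)cc1)CCC=C(C)C`) has 2,4,5-trifluorophenyl in place of 4-fluorophenyl on a nitrogen on an aromatic ring and the rest of the structure stays the same. With no readable size to build on, no clear move in either direction is expected in this assay and the result may again be only a limit. The expected change is a step that the limit leaves unreadable from compound 2 to compound 3 and no more can be said of it. The estimated value for compound 3 is 45000 nM with an expected range from 20000 nM to 90000 nM for now.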

Compound 3, half-maximal effective concentration: > 43400 nM
Compound 3 was reported as a limit; the forecaster's own chance of this, stated with the estimate: 70%; the middle value lies beyond the limit too.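

In this assay compound 3 gives > 43400 nM, a limit of the assay and not a number, so no size can be read for the change from compound 2 to compound 3. The compounds shown leave open whether any change to the shared core would give a measurable number: the limit of > 43400 nM in this assay, at which 3 of the 3 values shown sit.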